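A Shared Swap Applied to a Differently Joined Core

This account rests on a few compounds, and the source may have more. Where it says the series, first, only, none or still open, it means among the compounds named here.

Compound 1 `CCCCOc1ccc(C(=O)NNC(=O)c2ccc(NS(=O)(=O)c3cnc(O)nc3O)cc2)cc1` and compound 2 `Cc1ccccc1C(=O)NNC(=O)c1ccc(NS(=O)(=O)c2cnc(O)nc2O)cc1` have the same core and differ in one place: 2-methylphenyl in place of 4-butoxyphenyl on a carbonyl carbon. In a functional assay on A549 cells (Homo sapiens) for antiproliferative activity, read by MTT assay, with a stated time of 24 h (on this read-out lower numbers stand for stronger inhibition and higher numbers for weaker inhibition), compound 1 gives 9010 nM and compound 2 gives 15100 nM, which amounts to a 1.7-fold higher number from compound 1 to compound 2 (0.22 log units; within the scatter).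

Compound 3 `CCCCOc1ccc(C(=O)NNC(=O)c2ccccc2NS(=O)(=O)c2cnc(O)nc2O)cc1` is built from the same atoms as compound 1, but joined differently; the difference between the two cores is not broken down here. In this assay compound 3 gives 4960 nM.

Compound 4 `Cc1ccccc1C(=O)NNC(=O)c1ccccc1NS(=O)(=O)c1cnc(O)nc1O` has not yet been measured in this assay. It stands to compound 3 as compound 2 stands to compound 1, the same change at the same place: 2-methylphenyl in place of 4-butoxyphenyl on a carbonyl carbon. Compound 4 is expected to give 8400 nM, with a likely range from 4000 nM to 18000 nM. Within the data shown here, this estimate amounts to a 1.7-fold higher number from compound 3 to compound 4 (0.23 log units; within the scatter), and it rests on the single earlier example of this change, which gave a 1.7-fold higher number from compound 1 to compound 2 (0.22 log units; within the scatter); with only one prior case and a core that is joined differently, the range is kept wide.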

Compound 4, half-maximal inhibitory concentration: 5450 nM
Estimate against measurement, compound 4: 1.5-fold (0.19 log units) above, and the stated range covers the measured number.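

On the differently joined core, the same swap of 4-butoxyphenyl for 2-methylphenyl gives a 1.1-fold higher number from compound 3 to compound 4 (0.04 log units; within the scatter) in this assay. Set beside the earlier case, the two steps cannot be told apart, so within these two pairs the change carries from one core to the other without a detectable difference: the same change on two cores in this assay, a 1.7-fold higher number (0.22 log units; within the scatter) from compound 1 to compound 2 and a 1.1-fold higher number (0.04 log units; within the scatter) from compound 3 to compound 4, 1.5-fold (0.18 log units) apart, within the scatter of two such steps. This does not show that the swap is without effect in general, since both steps lie within the scatter, a small real step could hide inside them, and two pairs cannot predict what would happen on a third core.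

From the compounds shown here alone, both groups compared on this carbonyl carbon are rings of carbon only, so it remains open whether a pyridine ring, a carboxylic acid or an amine in that place would move the number beyond the scatter. Going by these compounds, it also remains open how a plain phenyl, carrying neither the butoxy chain nor the methyl, would compare on either core.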